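Orexin receptor type 2 series: sulfonamide to carbamic acid

The source may hold more compounds than are shown below. What is called first, only, known or untested is meant among the compounds shown, and "the series" means these compounds.

Of the compounds shown here, two have a number so far. Compound 1 `CCS(=O)(=O)NC1CCCN(C(C)=O)C1COC1CCC(C(C)C)CC1` is the unresolved parent; in a functional assay on CHO-K1 cells for agonist activity at Orexin receptor type 2 (Homo sapiens), read by FLIPR and calcium flux (a lower number here means that less compound is needed, a higher number that more compound is needed for the effect), compound 1 gives 570 nM. Compound 2 `CC(=O)N1CCC[C@H](NS(C)(=O)=O)[C@@H]1CO[C@H]1CC[C@@H](C(C)C)CC1` is the single stereoisomer with defined centres; in this assay compound 2 gives 330 nM. Going by the values given here, the gap between these two numbers lies within the usual scatter of repeated runs, so the two compounds cannot be told apart on the present data, and no trend across the pair can be claimed.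

Compound 3 `CC(=O)N1CCC[C@H](NC(=O)O)[C@@H]1CO[C@H]1CC[C@@H](C(C)C)CC1` keeps the whole of compound 2 except for one exchange on the amine nitrogen: carboxy in place of methylsulfonyl on an amine nitrogen. Among the compounds with values here, no measured pair shows this exchange, so there is no step to lean on. A sulfonamide giving way to a carboxyamino group is a large change at the only hydrogen-bond donor of the side chain, and a step beyond the scatter toward a higher number is expected rather than a neutral one.

For compound 3 in this assay the estimate is 2500 nM, with a range of 700 nM to 10000 nM, which corresponds to an expected step of a 7.6-fold higher number from compound 2 to compound 3 (0.88 log units; beyond the scatter).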

Compound 3, half-maximal effective concentration: > 30000 nM
Compound 3 was reported as a limit; the forecaster's own chance of this, stated with the estimate: 25%; at least 12-fold (1.07 log units) between middle value and limit.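

In this assay compound 3 is reported only as a limit, > 30000 nM. Going by these compounds alone, compound 1 and compound 2 both carry a sulfonyl group on the amine nitrogen, so they could not show whether this place tolerates its replacement; carboxy in place of methylsulfonyl gives an at least 90-fold higher number from compound 2 to compound 3 (1.95 log units; beyond the scatter), the first step beyond the scatter, and the substituent on this nitrogen therefore matters for the read-out, with the rest of compound 2 unchanged. The size of this step is bounded from one side only, and its true extent cannot be read: the limit of > 30000 nM in this assay, at which 1 of the 3 values shown sits.

Open, from the compounds shown here alone, is whether the higher number belongs to the carboxy group in particular or to any departure from a sulfonyl group on this nitrogen; a methoxycarbonyl or an acetyl group at the same place would separate the two readings. Also open is how much room the sulfonyl side itself offers, since a propylsulfonyl or a cyclopropylsulfonyl group on the single stereoisomer of compound 2 would extend the comparison beyond the one exchange shown here.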